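The compounds below may be only part of what the source reports. "The series", "measured", "known", "first", "only" and "open" are said of these compounds alone.

Measured compounds:
Compound 1, `COC(=O)[C@@]1(C)CCC=C2[C@@H]1CC[C@@H](C)[C@]2(C)Cc1c(C)[nH]c2ccccc12`, gives 14000 nM in a functional assay on SW1573 cells (Homo sapiens) for inhibition, read by sulforhodamine B assay, with a stated time of 48 h; on this read-out lower numbers stand for stronger inhibition of growth and higher numbers for weaker inhibition of growth.
Compound 2, `COC(=O)[C@@]1(C)CCC=C2[C@@H]1CC[C@@H](C)[C@]2(C)Cc1c(C)[nH]c2ccc(C)cc12`, gives 18000 nM in this assay.
Compound 3, `COC(=O)[C@@]1(C)CCC=C2[C@@H]1CC[C@@H](C)[C@]2(C)Cc1c(C)[nH]c2ccc(Br)cc12`, gives 14000 nM in this assay.

Compound 3 stands level with compound 1 at the digits shown, and together they hold the lowest of the three numbers; the step of a 1.3-fold lower number from compound 2 to compound 3 (0.11 log units; within the scatter) does not go beyond the scatter. The step to compound 4, `COC(=O)[C@@]1(C)CCC=C2[C@@H]1CC[C@@H](C)[C@]2(C)Cc1c(C)[nH]c2ccc(Cl)cc12`, is chloro in place of bromo on an aromatic carbon.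

For the measured compounds named here, two measured steps bear on this position. The step of no change at the digits printed from compound 1 to compound 3 (within the scatter) shows that putting bromo in place of hydrogen left the number unchanged at the digits shown, and the step of a 1.3-fold higher number from compound 1 to compound 2 (0.11 log units; within the scatter) shows that methyl in place of hydrogen moved it only within the scatter. Nothing in these three compounds suggests that a halogen at this position shifts growth inhibition in this assay one way or the other.

Compound 4 is therefore expected to stay close to compound 3, with a step of no change at the digits printed from compound 3 to compound 4 (within the scatter), inside the scatter. The estimate for compound 4 in this assay is 14000 nM, with a range from 7000 nM to 28000 nM.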

Compound 4, concentration for 50% growth inhibition: 14000 nM
Estimate against measurement, compound 4: no gap at the digits printed; measured number inside the range.
By their numbers in this assay, from the lowest: compounds 1, 3, 4 and 2 (each within the scatter of the next).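

In this assay, chloro in place of bromo on an aromatic carbon gives no change at the digits printed from compound 3 to compound 4 (within the scatter), so the two halogens cannot be told apart at this position. Chloro in place of hydrogen gives no change at the digits printed from compound 1 to compound 4 (within the scatter), and chloro in place of methyl gives a 1.3-fold lower number from compound 2 to compound 4 (0.11 log units; within the scatter), so the flat result seen earlier with bromo also holds for a second halogen. Hydrogen, methyl, bromo and chloro at this position now all lie within the scatter of one another.

As far as these compounds go, whether an amine, a carboxylic acid or a longer chain at this position would move the number beyond the scatter stays open, as does the effect of any change elsewhere on the shared core. No measurement given here accounts for this flat result.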